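A Second Chloro on the Core of Compound 1

The source may report more compounds than this note shows. Statements on the series, on what has been measured and on what is new or still open speak of the compounds shown alone.

Compound 1 `ClCc1ccccc1Cn1cnc2ncnc(Cl)c21` carries a single chloro on its fused core. In a functional assay on NCI-H460 cells (Homo sapiens) for cytotoxicity, read by sulforhodamine B assay, with a stated time of 48 h (a lower number here means that less compound is tolerated, a higher number that more compound is tolerated), compound 1 gives > 100000 nM, which is a limit of the assay and not a measured number (the limit of > 100000 nM in this assay, at which 1 of the 2 values shown sits). Compound 2 `ClCc1cccc(Cn2cnc3nc(Cl)nc(Cl)c32)c1` has two chloro groups on the core and a different arrangement of the same pieces; in this assay compound 2 gives 5490 nM. Compound 3 `ClCc1ccccc1Cn1cnc2nc(Cl)nc(Cl)c21` is made from compound 1 by one change, (chloro in place of hydrogen on an aromatic carbon), chloro in place of hydrogen on an aromatic carbon. Within the data shown here, no measured pair shows this exact step, so its size is open. The step from compound 1 to compound 3 is expected to be an at least 5.0-fold lower number from compound 1 to compound 3 (0.69 log units; beyond the scatter), moving compound 3 below the limit. This expectation rests on compound 2, which with two chloro groups gives 5490 nM. Compound 3 is estimated at 20000 nM, within a range of 5000 nM to 100000 nM.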

Compound 3, concentration lethal to 50% of the cells: > 100000 nM
Compound 3: a limit, no number; the forecaster's own chance of this, stated with the estimate: 30%; at least 5.0-fold (0.69 log units) between middle value and limit.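

In this assay, compound 1 and compound 3 both end at a limit and not at a measured number, so no step can be read between them: the limit of > 100000 nM in this assay, at which 2 of the 3 values shown sit.

The compounds shown leave open whether chloro in place of hydrogen on an aromatic carbon changes the lethal concentration of compound 1 at all.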